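This account rests on a few compounds, and the source may have more. Where it says the series, first, only, none or still open, it means among the compounds named here.

Compound 1 `CSc1nc(NCCCCNc2ccnc3cc(Cl)ccc23)c(C#N)c(-c2ccccc2)n1`: 5200 nM
Compound 2 `CSc1nc(OCCCNc2ccnc3cc(Cl)ccc23)c(C#N)c(-c2ccccc2)n1`: 3300 nM

In an ADME assay on CCRF-CEM cells (Homo sapiens) for inhibition, read by cell counting (on this read-out lower numbers stand for stronger inhibition and higher numbers for weaker inhibition), compound 1 gives 5200 nM, the higher of the two numbers, though its gap to compound 2 lies within the scatter; compound 2 gives 3300 nM. Compound 3 `CSc1nc(NCCCCNc2ccnc3cc(Cl)ccc23)c(C#N)c(-c2ccc([N+](=O)[O-])cc2)n1` differs from compound 1 by nitro in place of hydrogen on an aromatic carbon. Within the data shown here, no measured pair shows this change, so no step beyond the scatter in either direction is expected, the estimated step being a 1.0-fold lower number from compound 1 to compound 3 (0.02 log units; within the scatter). Compound 3 is therefore expected to give about 5000 nM, with a range from 2000 nM to 12000 nM.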

Compound 3, half-maximal inhibitory concentration: 760 nM
For compound 3 the middle estimate is 6.6-fold (0.82 log units) above the measured one; measured number outside the range, below it.
By their numbers in this assay, from the lowest: compound 3; then compounds 2 and 1 (each within the scatter of the next).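

Among these compounds, this position on the phenyl ring clearly matters: in this assay the change from phenyl to 4-nitrophenyl gives a 6.8-fold lower number from compound 1 to compound 3 (0.84 log units; beyond the scatter) and is the only step here that can be read beyond the scatter. A single nitro group at this place, para to a large group, is therefore enough to shift the number. Nothing measured here explains the shift. Still open, on these data alone, is whether another group at this place, such as an amine or a chlorine atom, would move the number as far. Also open, as far as these compounds go, is whether nitro would do the same on compound 2.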